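Ethoxy in Place of Methyl on a Hydroxamate Core

The source may report more compounds than this note shows. Statements on the series, on what has been measured and on what is new or still open speak of the compounds shown alone.

Compound 2 `Cc1ccc2nc(NC(=O)CCCCC(=O)NO)sc2c1` gives 4.69 ug/mL in a functional assay on SW-620 cells (Homo sapiens) for cytotoxicity (on this read-out higher numbers stand for weaker inhibition and lower numbers for stronger inhibition), and its nearest neighbour, compound 1 `O=C(CCCCC(=O)Nc1nc2ccccc2s1)NO`, gives 7.85 ug/mL; the two lie within the scatter of each other. Compound 3 `CCOc1ccc2nc(NC(=O)CCCCC(=O)NO)sc2c1` differs from compound 2 by ethoxy in place of methyl on an aromatic carbon. Among the measured compounds shown here, the only step measured at this aromatic carbon, a 1.7-fold lower number from compound 1 to compound 2 (0.22 log units; within the scatter), stayed within the scatter, and no measured step replaces methyl with ethoxy, so there is little to guide a shift in either direction. Compound 3 is therefore expected to stay near compound 2, with an estimated step of a 1.0-fold lower number from compound 2 to compound 3 (0.02 log units; within the scatter). The estimated value of compound 3 is 4.5 ug/mL, expected between 1.8 ug/mL and 11 ug/mL.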

Compound 3, half-maximal inhibitory concentration: 9.26 ug/mL
Estimate against measurement, compound 3: 2.1-fold (0.31 log units) below; measured number inside the range.
By their numbers in this assay, from the lowest: compounds 2, 1 and 3 (each within the scatter of the next).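

In this assay ethoxy in place of methyl on this aromatic carbon gives a 2.0-fold higher number from compound 2 to compound 3 (0.30 log units; within the scatter) and stays within the scatter, and ethoxy in place of hydrogen gives a 1.2-fold higher number from compound 1 to compound 3 (0.07 log units; within the scatter) and stays within it too. With hydrogen, methyl and ethoxy on this carbon, the three compounds all lie within the scatter of one another, so none of these groups separates from the others on this read-out. Nothing available explains these numbers. From the compounds shown here alone, whether an amine or a carboxylic acid on this aromatic carbon would give a number beyond that scatter stays open, as does the outcome for a longer chain in place of ethoxy.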